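Swapping chloro for hydrogen on compound 1

The compounds below may be only part of what the source reports. "The series", "measured", "known", "first", "only" and "open" are said of these compounds alone.

Of the compounds shown here, two have numbers so far. In an ADME assay for permeability (a higher number here means that the compound crosses the layer faster, a lower number that the compound crosses the layer more slowly), compound 1 (`CNC(=O)c1cc(C(=O)N[C@H]2CC[C@H](O)CC2)n([C@@H](C)c2ccc(Cl)cc2)n1`) gives 180 nm/s, the higher of the two, while compound 2 (`CNC(=O)c1cc(C(=O)N[C@H]2CC[C@H](O)CC2)c([C@@H](C)c2cccc(F)c2)o1`) gives 73 nm/s, a gap beyond the usual scatter of repeated measurements. Compound 1 therefore stands at the top of this short list.

Compound 3 (`CNC(=O)c1cc(C(=O)N[C@H]2CC[C@H](O)CC2)n([C@@H](C)c2ccccc2)n1`) is still unmeasured. It differs from compound 1 in a single place, hydrogen in place of chloro on an aromatic carbon, so that 4-chlorophenyl becomes phenyl. Compounds 1 and 2 differ in more than one place, so they offer no direct reading of this change. In this assay the expected step, a 1.3-fold lower number from compound 1 to compound 3 (0.11 log units; within the scatter), is small, downward and within the scatter. Compound 3 is expected at 140 nm/s, with an estimated range of 75 nm/s to 260 nm/s.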

Compound 3, apparent permeability: 80 nm/s
Beside the measured number, compound 3's estimate is 1.8-fold (0.24 log units) above it, within the range that was stated.
By their numbers in this assay, from the lowest: compounds 2 and 3 (each within the scatter of the next); then compound 1.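

For the compounds shown here, compounds 1 and 2 differ in more than one place, so this is the first direct reading of a single change: in this assay, putting hydrogen in place of chloro on 4-chlorophenyl gives a 2.3-fold lower number from compound 1 to compound 3 (0.35 log units; beyond the scatter). The step is modest but beyond the scatter, so a single chlorine at this place, with the rest of the molecule unchanged, makes a measurable difference to the number. No available measurement gives a reason for this step.

On these data alone, whether other groups at this place, such as methoxy or an amine, would keep the number of compound 1 or move it further remains open. Also open, as far as these compounds go, is whether the same swap of chloro for hydrogen would give a step of similar size on the core of compound 2.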